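Chloro for Fluoro on a Six-Membered Aromatic Ring

A few compounds are considered here, and "the series" means these few. Any claim that something is new, unique, unknown or untested is made for them only; others in the source may bear on it.

All four compounds share one core and differ only in the ring attached to a nitrogen. Compound 3 `COc1cc2ncnc(Nc3ccc(F)cc3)c2cc1OCCCCC(=O)Nc1ccc(S(N)(=O)=O)cc1` gives 18600 nM in a functional assay on A-431 cells (Homo sapiens) for antiproliferative activity, read by MTT assay, with a stated time of 72 h (on this read-out lower numbers stand for stronger inhibition and higher numbers for weaker inhibition), the second highest of the three numbers measured. Compound 1 `COc1cc2ncnc(Nc3ccc(F)c(Cl)c3)c2cc1OCCCCC(=O)Nc1ccc(S(N)(=O)=O)cc1` gives 5020 nM and compound 2 `COc1cc2ncnc(Nc3cccc(F)c3)c2cc1OCCCCC(=O)Nc1ccc(S(N)(=O)=O)cc1` gives 29900 nM. The step of a 3.7-fold higher number from compound 1 to compound 3 (0.57 log units; beyond the scatter) is modest but beyond the scatter, a 6.0-fold higher number from compound 1 to compound 2 (0.77 log units; beyond the scatter) points the same way, and a 1.6-fold lower number from compound 2 to compound 3 (0.21 log units; within the scatter) is within the scatter. Compound 4 `COc1cc2ncnc(Nc3ccc(Cl)cc3)c2cc1OCCCCC(=O)Nc1ccc(S(N)(=O)=O)cc1` carries chloro in place of fluoro on an aromatic carbon, para to a large group. Within the data shown here, the only measured step that touches a chloro is a 3.7-fold higher number from compound 1 to compound 3 (0.57 log units; beyond the scatter). Compound 4 is therefore expected to show a 2.1-fold lower number from compound 3 to compound 4 (0.32 log units; beyond the scatter), with an estimated value of 9000 nM, ranging from 4000 nM to 20000 nM.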

Compound 4, half-maximal inhibitory concentration: 7120 nM
Compound 4: middle estimate off by 1.3-fold (0.10 log units), on the high side; the measured number falls inside the stated range.
By their numbers in this assay, from the lowest: compounds 1 and 4 (each within the scatter of the next); then compounds 3 and 2 (each within the scatter of the next).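

Placed para to a large group, chloro in place of fluoro gives a 2.6-fold lower number from compound 3 to compound 4 (0.42 log units; beyond the scatter) in this assay, so this single-atom change at this position is measurable on its own. The 4-chlorophenyl group also stands clear of 3-fluorophenyl, with a 4.2-fold lower number from compound 2 to compound 4 (0.62 log units; beyond the scatter), while against 3-chloro-4-fluorophenyl it gives a 1.4-fold higher number from compound 1 to compound 4 (0.15 log units; within the scatter). Nothing measured here gives a reason for these differences. Still open, from the compounds shown here alone, is how a bromo, a methyl or an amine at this same position would read. A longer chain on the shared core could also change the size of the chloro-for-fluoro step.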